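Moving the Hydroxyl Around a Pyridine-Bearing Scaffold

This account rests on a few compounds, and the source may have more. Where it says the series, first, only, none or still open, it means among the compounds named here.

Among the compounds with values here, compound 3 `Oc1cccc(-c2cc(-c3cccnc3)cc(-c3ccccc3O)n2)c1` gives 8280 nM in a functional assay on HCT-15 cells (Homo sapiens) for cytotoxicity, read by CCK-8 assay (a higher number here means a weaker inhibitor, a lower number a stronger inhibitor), the only number among the three values measured so far. The other two are limits of the assay. Compound 1 `Oc1ccc(-c2cc(-c3ccco3)cc(-c3ccccc3O)n2)cc1` returns a limit of > 50000 nM in this assay. Compound 2 `Oc1ccc(-c2cc(-c3ccccn3)cc(-c3ccccc3O)n2)cc1` likewise returns a limit of > 50000 nM in this assay. The step that the two limits leave unreadable from compound 1 to compound 2 therefore cannot be read. Compound 4 `Oc1ccc(-c2cc(-c3cccnc3)cc(-c3ccccc3O)n2)cc1` differs from compound 3 by 4-hydroxyphenyl in place of 3-hydroxyphenyl on an aromatic carbon. Within the data shown here, no measured step covers this change directly. Among the measured compounds shown here, compound 1 and compound 2, which both carry the 4-hydroxyphenyl group that enters here, sit at the limit of > 50000 nM in this assay, at which 2 of the 3 values shown sit, while compound 3 with 3-hydroxyphenyl is the one compound with a measurable value. On this basis the step from compound 3 to compound 4 in this assay is expected to go toward weaker inhibition, with a real chance that compound 4 also reaches the limit. The step expected is a 3.0-fold higher number from compound 3 to compound 4 (0.48 log units; beyond the scatter). Compound 4 is estimated at 25000 nM in this assay, within a range from 6000 nM to 60000 nM.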

Compound 4, half-maximal inhibitory concentration: > 50000 nM
Compound 4 gave a limit, no number; the forecaster's own chance of this, stated with the estimate: 40%; middle value at least 2.0-fold (0.30 log units) away from the limit.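

Within the data shown here, with the pyridin-3-yl group held fixed, moving the hydroxyl from 3-hydroxyphenyl to 4-hydroxyphenyl gives an at least 6.0-fold higher number from compound 3 to compound 4 (0.78 log units; beyond the scatter) in this assay, the first step whose size has a bound. The steps to compound 4 from compound 1 and from compound 2 cannot be read, so swapping furan-2-yl, pyridin-2-yl and pyridin-3-yl shows no measurable effect while 4-hydroxyphenyl is present. Among these compounds, compound 3 remains the only compound with a number, and every compound carrying 4-hydroxyphenyl now sits at the limit: the limit of > 50000 nM in this assay, at which 3 of the 4 values shown sit. As far as these compounds go, it remains open what 3-hydroxyphenyl would give alongside furan-2-yl or pyridin-2-yl. Also open, from the compounds shown here alone, is whether a methoxy group or an amine in place of the hydroxyl of 3-hydroxyphenyl would keep the value seen for compound 3.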